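A second fluoro on compound 2

The source may hold more compounds than are shown below. What is called first, only, known or untested is meant among the compounds shown, and "the series" means these compounds.

compound 1 `Nc1nc(N)c2cc(CSC(=S)N3CCN(c4ccc(O)cc4)CC3)ccc2n1` gives 5980 nM
compound 2 `Nc1nc(N)c2cc(CSC(=S)N3CCN(c4ccc(F)cc4)CC3)ccc2n1` gives 3270 nM

Measured in a functional assay on HCT-116 cells (Homo sapiens) for antiproliferative activity, read by MTT assay, with a stated time of 72 h (on this read-out lower numbers stand for stronger inhibition and higher numbers for weaker inhibition), compound 2 gives 3270 nM and stands within the scatter of compound 1 at 5980 nM in this small set. Compound 3 `Nc1nc(N)c2cc(CSC(=S)N3CCN(c4ccc(F)cc4F)CC3)ccc2n1` differs from compound 2 by fluoro in place of hydrogen on an aromatic carbon in which fluoro takes the place of hydrogen on an aromatic carbon, turning 4-fluorophenyl into 2,4-difluorophenyl. Going by the values given here, only one measured step bears on this, and only loosely: a 1.8-fold lower number from compound 1 to compound 2 (0.26 log units; within the scatter) also puts fluoro on an aromatic carbon, and it stays within the scatter. Among the compounds with values here, no measured compound carries a group at the new place, ortho to a large group. No step beyond the scatter is therefore expected, in either direction. The expected change is a 1.1-fold lower number from compound 2 to compound 3 (0.04 log units; within the scatter) and remains an estimate. Compound 3 is estimated at 3000 nM with 1300 nM to 7000 nM as the expected range.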

Compound 3, half-maximal inhibitory concentration: 5150 nM
Compound 3: the middle estimate sits 1.7-fold (0.23 log units) below what was measured, within the range that was stated.
By their numbers in this assay, from the lowest: compounds 2, 3 and 1 (each within the scatter of the next).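

In this assay, going by these compounds alone, adding fluoro ortho to a large group, a place that no earlier compound filled, gives a 1.6-fold higher number from compound 2 to compound 3 (0.20 log units; within the scatter) and so produces no step beyond the scatter. Replacing 4-hydroxyphenyl with 2,4-difluorophenyl also stays within the scatter (a 1.2-fold lower number from compound 1 to compound 3 (0.06 log units; within the scatter)), so the three aryl groups shown are not told apart on this read-out. No evidence is available that bears on this result.

On these data alone, whether a larger group at that place, such as chloro or methoxy, would also stay within the scatter remains open. Also open, as far as these compounds go, is how the number would respond if an amine stood on the ring in place of the 4-fluoro group, or if a plain alkyl chain replaced the aryl group altogether.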